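Cytotoxicity of a Cyanophenyl Analogue in Karpas-1106P Cells

The source may report more compounds than this note shows. Statements on the series, on what has been measured and on what is new or still open speak of the compounds shown alone.

Compound 1 `Cc1ccc(S(=O)(=O)N[C@@H](CC(=O)NC(C)(C)C)C(=O)NCCNC(=O)c2c(O)cccc2F)cc1`: > 11100 nM
Compound 2 `Cc1ccc(S(=O)(=O)N[C@@H](CC(=O)NC(C)(C)C)C(=O)NCCNC(=O)c2ccccc2F)cc1`: > 11100 nM

In an ADME assay on Karpas-1106P cells (Homo sapiens) for cytotoxicity (on this read-out lower numbers stand for an effect already at smaller amounts and higher numbers for an effect only at larger amounts of compound), compound 1 reaches only the limit > 11100 nM. Compound 2 likewise reaches only the limit > 11100 nM. The step that the two limits leave unreadable from compound 1 to compound 2 is therefore unreadable, since the limit of > 11100 nM in this assay, at which 2 of the 2 values shown sit, covers both values. Compound 3 `Cc1ccc(S(=O)(=O)N[C@@H](CC(=O)NC(C)(C)C)C(=O)NCCNC(=O)c2cccc(C#N)c2)cc1` differs from compound 2 by 3-cyanophenyl in place of 2-fluorophenyl on a carbonyl carbon. Going by the values given here, no measured step in this assay is readable, and the only evidence is the limit of > 11100 nM in this assay, at which 2 of the 2 values shown sit. Compound 3 is therefore expected to give 15000 nM in this assay, within 7000 nM to 40000 nM, most likely again as a limit, a step that the limit leaves unreadable from compound 2 to compound 3 that is expected to stay within the scatter.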

Compound 3, half-maximal effective concentration: > 11100 nM
Compound 3: no number, only a limit (the forecaster's own chance of this, stated with the estimate: 85%); the middle value does not contradict the limit.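

In this assay compound 3 gives only the limit > 11100 nM and no number. Its steps from compound 1 and compound 2 therefore cannot be read: the limit of > 11100 nM in this assay, at which 3 of the 3 values shown sit. The compounds shown leave open whether any of these changes alters cytotoxicity, and at what concentration any of them would act.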